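The source may report more compounds than this note shows. Statements on the series, on what has been measured and on what is new or still open speak of the compounds shown alone.

Compound 1 `O=C1C(Nc2ccccc2F)=CC(=O)c2c1nc1n2[C@H]2OC[C@@H](O)[C@H]2OC1` and compound 2 `O=C1C(NC2CC2)=CC(=O)c2c1nc1n2[C@H]2OC[C@@H](O)[C@H]2OC1` share one core and differ only in the group on the amine nitrogen. In a functional assay on MGC-803 cells (Homo sapiens) for inhibition, read by sulforhodamine B assay (on this read-out lower numbers stand for stronger inhibition and higher numbers for weaker inhibition), compound 1 gives 2000 nM. Compound 2 reaches only a limit of this assay, > 4000 nM, and no number. Among the measured compounds shown here, the single measured step, an at least 2.0-fold higher number from compound 1 to compound 2 (0.30 log units; that floor lies within the scatter), accordingly rests on the limit of > 4000 nM in this assay, at which 1 of the 2 values shown sits, and gives a floor for the change rather than a full size.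

Compound 3 `O=C1C(Nc2cccc(Cl)c2)=CC(=O)c2c1nc1n2[C@H]2OC[C@@H](O)[C@H]2OC1` is the next member: 3-chlorophenyl in place of cyclopropyl on an amine nitrogen. This change puts an aryl group back on the amine nitrogen, as in compound 1, so the step from compound 1 to compound 2 is the one that bears on it, read in reverse. For compound 3 the step of an at least 2.0-fold lower number from compound 2 to compound 3 (0.30 log units; that floor lies within the scatter) is expected, toward stronger inhibition, with a number of the order seen for compound 1. Compound 3 is therefore estimated at 2000 nM, within 700 nM to 6000 nM.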

Compound 3, half-maximal inhibitory concentration: 1530 nM
Compound 3: middle estimate off by 1.3-fold (0.12 log units), on the high side; measured number inside the range.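

In this assay, replacing cyclopropyl with an aryl group now gives a step that clears the scatter, an at least 2.6-fold lower number from compound 2 to compound 3 (0.41 log units; beyond the scatter), whereas the earlier floor stayed within it. The two aryl groups do not separate, with 2-fluorophenyl and 3-chlorophenyl on the amine nitrogen giving a 1.3-fold lower number from compound 1 to compound 3 (0.12 log units; within the scatter), which lies within the scatter. Compound 2 holds a limit and not a number, so the step from it gives only a floor for the change: the limit of > 4000 nM in this assay, at which 1 of the 3 values shown sits.

The compounds shown leave open whether an aromatic ring directly on the amine nitrogen is needed, or whether a benzyl group or a longer alkyl chain would give similar numbers. Also open, going by these compounds, is how the number responds to an amine or a carboxylic acid on the phenyl ring.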